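The source may report more compounds than this note shows. Statements on the series, on what has been measured and on what is new or still open speak of the compounds shown alone.

Measured in a functional assay on MCF7 cells (Homo sapiens) for cytotoxicity, read by MTT assay, with a stated time of 72 h; a higher number here means a weaker inhibitor, a lower number a stronger inhibitor:

- compound 1 `COc1ccc(/C=C2\CCC/C(=C\c3cccc(Cl)c3)C2=O)cc1OC` gives 6000 nM
- compound 2 `COc1ccccc1/C=C1\CCC/C(=C\c2ccc(OC)c(OC)c2)C1=O` gives 8000 nM
- compound 3 `COc1cccc(/C=C2\CCC/C(=C\c3ccc(OC)c(OC)c3)C2=O)c1` gives 4600 nM

Compound 3 cannot be separated from the other two, as a 1.3-fold lower number from compound 1 to compound 3 (0.12 log units; within the scatter) and a 1.7-fold lower number from compound 2 to compound 3 (0.24 log units; within the scatter) both lie within the scatter. Compound 4 `COc1ccc(/C=C2\CCC/C(=C\c3ccc(Cl)c(Cl)c3)C2=O)cc1OC` carries 3,4-dichlorophenyl in place of 3-methoxyphenyl on a double-bonded chain carbon bound to a double-bonded ring carbon. The closest measured change, methoxy in place of chloro on an aromatic carbon, is a 1.3-fold lower number from compound 1 to compound 3 (0.12 log units; within the scatter), and it stays within the scatter. Going by the values given here, no measured compound carries the entering group itself, so no step beyond the scatter is expected in this assay. The estimated step is a 1.1-fold higher number from compound 3 to compound 4 (0.04 log units; within the scatter). Compound 4 is expected near 5000 nM, with an estimated range of 2000 nM to 12000 nM.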

Compound 4, half-maximal inhibitory concentration: 4400 nM
Compound 4: middle estimate off by 1.1-fold (0.06 log units), on the high side; measured number inside the range.
By their numbers in this assay, from the lowest: compounds 4, 3, 1 and 2 (each within the scatter of the next).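

In this assay the 3,4-dichlorophenyl group on a double-bonded chain carbon bound to a double-bonded ring carbon cannot be told apart from either methoxyphenyl group, with a 1.0-fold lower number from compound 3 to compound 4 (0.02 log units; within the scatter) and a 1.8-fold lower number from compound 2 to compound 4 (0.26 log units; within the scatter) as the two readings. Chloro in place of hydrogen on an aromatic carbon, the first single-atom addition here, gives a 1.4-fold lower number from compound 1 to compound 4 (0.13 log units; within the scatter) and so also stays flat. Nothing available explains why these groups read alike.

Every group shown at this place is a substituted phenyl ring. From the compounds shown here alone, whether an amine or a carboxylic acid there would move the number beyond the scatter remains open.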